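Closing the hydroxyhexyl chain into a hydroxycyclohexyl ring

A few compounds are considered here, and "the series" means these few. Any claim that something is new, unique, unknown or untested is made for them only; others in the source may bear on it.

Measured compounds:
compound 1, `CCCCN(CCCC)Cc1cn(C2CCCCC2OC(=O)COc2ccccc2)nn1`: 26%
compound 2, `CCCCC(O)Cn1cc(CN(CCCC)CCCC)nn1`: 18%

In an assay on nucleic acid for inhibition of Nucleic Acid, read by fluorescence, tested at 100 uM (a higher number here means more inhibition at the concentration tested (going by the name of the read-out), a lower number less inhibition), compound 1 gives 26%. In the same test compound 2 gives 18%. Compound 2 holds the lower of the two numbers, but its gap to compound 1 lies within the scatter, so the two cannot be ordered against each other. Compound 3 `CCCCN(CCCC)Cc1cn(C2CCCCC2O)nn1` has not yet been measured in this assay. It differs from compound 2 in one place: 2-hydroxycyclohexyl in place of 2-hydroxyhexyl on an aromatic nitrogen. Going by the values given here, no pair of measured compounds shows this change, so there is no measured step from which to read its effect. Both measured compounds sit in the same modest region of inhibition, and the change keeps the hydroxyl and the count of heavy atoms, so the expected step of a number 4 percentage points higher from compound 2 to compound 3 (within the scatter) is none beyond the scatter. Compound 3 is therefore estimated to give 22%, within 8% to 38%.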

Compound 3, a percentage reported as inhibition, at one concentration (the size of the read-out at that concentration, not a potency): 32%
Beside the measured number, compound 3's estimate is 10 percentage points below it, within the range that was stated.
By their numbers in this assay, from the lowest: compounds 2, 1 and 3 (each within the scatter of the next, the first and the last beyond it).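

Going by these compounds alone, on the aromatic nitrogen, 2-hydroxycyclohexyl in place of 2-hydroxyhexyl gives a number 14 percentage points higher from compound 2 to compound 3 (beyond the scatter) in this assay, so this position tells the ring from the open chain even though both groups carry the same count of heavy atoms, which the earlier compounds could not show. Hydrogen in place of (phenoxymethyl)carbonyl on the oxygen gives a number 6 percentage points higher from compound 1 to compound 3 (within the scatter), so the larger group on that oxygen shows no measurable effect on the read-out in this pair. Nothing available bears on why the ring and the chain differ. On these data alone, whether the hydroxyl itself matters stays open, and a methoxy group or an amine in its place would test that. Also open, as far as these compounds go, is whether the step depends on ring size, which a cyclopentyl or cycloheptyl group on the same nitrogen would address.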